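This account rests on a few compounds, and the source may have more. Where it says the series, first, only, none or still open, it means among the compounds named here.

In a functional assay on the whole organism for agonist activity, with Mus musculus as the target (a higher number here means that more compound is needed for the effect, a lower number that less compound is needed), compound 1 `CC(=O)N(C)CC#CCn1cncc1C` gives 45 mg/kg. Compound 2 `CCOC(=O)N(C)CC#CCn1ccnc1` gives > 100 mg/kg in this assay, and this is a limit of the assay, not a number. As far as these compounds go, compound 2 therefore has no exact place on the scale, and its true dose remains unknown.

Compound 3 `CCOC(=O)N(C)CC#CCn1cncc1C` is compound 2 with a single change: methyl in place of hydrogen on an aromatic carbon. Going by the values given here, no measured pair of compounds isolates this change, so its effect cannot be read directly from the data. Among the compounds with values here, the only guide is that compound 1, the one measured compound carrying this methyl, gives 45 mg/kg. On that slim basis, a moderate fall in the required dose, beyond the usual scatter, is expected in this assay. The expected step is an at least 2.5-fold lower number from compound 2 to compound 3 (0.39 log units; beyond the scatter), and it remains approximate while compound 2 has only a limit. For compound 3, the estimated dose is 40 mg/kg, with an expected range from 12 mg/kg to 100 mg/kg. The range is wide, since it rests on so few measurements.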

Compound 3, dose for half-maximal effect: > 100 mg/kg
Compound 3 gave a limit, no number; the forecaster's own chance of this, stated with the estimate: 20%; at least 2.5-fold (0.39 log units) between middle value and limit.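

In this assay, compound 3 gives > 100 mg/kg, which is a limit of the assay and not a number, so the methyl on an aromatic carbon does not by itself bring the ethoxy compound to a measurable dose. The size of the methyl's effect cannot be read, because compound 2 and compound 3 both end at a limit: the limit of > 100 mg/kg in this assay, at which 2 of the 3 values shown sit.

The clearer result concerns the group on the carbonyl carbon: with the ring methyl kept, ethoxy in place of methyl on a carbonyl carbon gives an at least 2.2-fold higher number from compound 1 to compound 3 (0.34 log units; beyond the scatter), so more compound is needed with ethoxy, and this single change matters in the whole animal.

The compounds shown leave open how far past the limit the true doses of compound 2 and compound 3 lie, and so whether the methyl changes the dose at all. They also leave open what a longer chain such as propoxy, or an amine, would do on the carbonyl carbon with the ring methyl kept.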